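This account rests on a few compounds, and the source may have more. Where it says the series, first, only, none or still open, it means among the compounds named here.

Going by the values given here, in an ADME assay on microsomes from liver (Homo sapiens) for metabolic stability, with a stated time of 60 min, tested at 1 uM (on this read-out lower numbers stand for a less stable compound and higher numbers for a more stable compound), compound 1 (`COc1cc(-c2cnn3cc(OC)c(C(C)C)nc23)ccn1`) gives 40% and compound 2 (`COc1cc(-c2cnn3cc(OC)c([C@@H]4COC(C)(C)C4)nc23)ccn1`) gives 13%, the lower of the two numbers so far. Compound 3 (`COc1cc(-c2cnn3cc(OC)c([C@H]4COC(C)(C)C4)nc23)ccn1`) is the next structure to read against compound 2: the two compounds have the same atoms and bonds and differ only in configuration as drawn: 1 of 1 stereo elements differ; a stereocentre at a saturated ring carbon is drawn R in compound 2 and S in compound 3. Among the compounds with values here, only one measured step exists, a number 27 percentage points lower from compound 1 to compound 2 (beyond the scatter). It bears on this change only indirectly, since it swaps one group for another and leaves configuration untested. Within the data shown here, no measured pair shows what inverting a stereocentre does in this assay, so the data give no size for such a step. The expectation therefore starts from compound 2 at 13%, with no shift beyond the scatter but a wide margin in either direction. The estimated step is a number 3 percentage points higher from compound 2 to compound 3 (within the scatter). For compound 3 the expected value is 16%, with an estimated range of 5% to 35%.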

Compound 3, percent of the compound remaining: 21%
Estimate against measurement, compound 3: 5 percentage points below; measured number inside the range.
By their numbers in this assay, from the lowest: compounds 2 and 3 (each within the scatter of the next); then compound 1.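

In this assay, inverting the stereocentre at the saturated ring carbon gives a number 8 percentage points higher from compound 2 to compound 3 (within the scatter), so this read-out does not separate the R and S forms as drawn, and the comparison isolates configuration alone: the fact that compounds 2 and 3 differ only in the configuration as drawn. The lower number for the five-membered ring in place of the group of 3 carbons on the aromatic carbon now appears with both configurations: a number 27 percentage points lower from compound 1 to compound 2 (beyond the scatter) and a number 19 percentage points lower from compound 1 to compound 3 (beyond the scatter). The step beyond the scatter therefore does not rest on one drawn form of the ring.

Open, from the compounds shown here alone, is whether the ring oxygen or the two methyl groups on the ring go with the lower numbers, which a cyclopentyl group on the same aromatic carbon would begin to test. Also open, going by these compounds, is whether an oxetane ring there would read closer to compound 1 at 40%.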